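This account rests on a few compounds, and the source may have more. Where it says the series, first, only, none or still open, it means among the compounds named here.

Measured so far:
compound 1 `COc1ccc(CN2CCC=C(CCC(=O)NO)C2=O)cc1`: 1670 nM
compound 2 `O=C(CCC1=CCCN(Cc2ccc(NC(=O)c3ccccc3)cc2)C1=O)NO`: > 10000 nM

All values come from a functional assay on ACHN cells (Homo sapiens) for inhibition, read by sulforhodamine B assay; on this read-out higher numbers stand for weaker inhibition of growth and lower numbers for stronger inhibition of growth. Compound 2 gives only a limit, > 10000 nM, and no number. The evidence here is thin: the limit of > 10000 nM in this assay, at which 1 of the 2 values shown sits.

Compound 3 `O=C(CCC1=CCCN(Cc2ccc(Br)cc2)C1=O)NO` differs from compound 2 as follows: bromo in place of benzamido on an aromatic carbon. In words, this is bromo in place of benzamido on an aromatic carbon, para to a large group.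

For the measured compounds named here, one measured step bears on this change: an at least 5.9-fold higher number from compound 1 to compound 2 (0.77 log units; beyond the scatter), with benzamido in place of methoxy. Losing benzamido is therefore expected to reverse much of that step, giving a move to lower numbers beyond the scatter. Going by the values given here, the landing point is expected near compound 1 at 1670 nM, although no measured compound carries bromo. The estimated step is an at least 6.6-fold lower number from compound 2 to compound 3 (0.82 log units; beyond the scatter). Compound 3 is expected at 1500 nM, with an estimated range of 500 nM to 5000 nM.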

Compound 3, concentration for 50% growth inhibition: 2480 nM
For compound 3 the middle estimate is 1.7-fold (0.22 log units) below the measured one, within the range that was stated.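

In this assay, the aromatic position para to a large group now carries two different groups, methoxy and bromo, that read alike: a 1.5-fold higher number from compound 1 to compound 3 (0.17 log units; within the scatter). Replacing benzamido with bromo gives an at least 4.0-fold lower number from compound 2 to compound 3 (0.60 log units; beyond the scatter), so among the compounds shown, only benzamido at this position goes with the higher number, and the earlier step is not simply a matter of losing methoxy. From the compounds shown here alone, the full size of this step stays unknown, as compound 2 gives only a limit: the limit of > 10000 nM in this assay, at which 1 of the 3 values shown sits.

Going by these compounds, it remains open whether an amine, a carboxylic acid or plain hydrogen at this position would read like bromo and methoxy. On these data alone, it is also open whether a shorter acetamido group would read like benzamido, or whether the loss needs the whole benzamido group with its aromatic ring.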